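The source may hold more compounds than are shown below. What is called first, only, known or untested is meant among the compounds shown, and "the series" means these compounds.

Working notes. Compound 3 `CCOC(=O)/C=C(C)/C=C/CC(C)CCCC(C)CC` stands highest of the three values in a physicochemical assay for lipophilicity; on this read-out higher numbers stand for higher lipophilicity and lower numbers for lower lipophilicity: compound 3 gives 7.81, with compound 2 `CCOC(=O)/C=C(C)/C=C/CC(C)CCCC(C)(C)OC(C)=O` nearest at 5.57 and compound 1 `CCOC(=O)/C=C(C)/C=C/CC(C)CCCC(C)(C)OC` furthest at 5.54. The steps of a number 2.27 log units higher from compound 1 to compound 3 (beyond the scatter) and a number 2.24 log units higher from compound 2 to compound 3 (beyond the scatter) are both large, whereas a number 0.03 log units higher from compound 1 to compound 2 (within the scatter) is not. Compound 4 `C=C(C)CCCC(C)C/C=C/C(C)=C/C(=O)OCC` differs from compound 3 in one place: 1-methylethenyl in place of sec-butyl on a saturated chain carbon, five bonds along the chain from a double-bonded chain carbon. Going by the values given here, no measured step shows this kind of exchange; the measured steps only show that changes at this place can move this assay strongly. The entering group is the smaller one by the counted difference, so a moderate step downward is expected, a number 0.71 log units lower from compound 3 to compound 4 (beyond the scatter). Compound 4 is therefore estimated at 7.1, between 6.6 and 7.6.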

Compound 4, partition coefficient: 6.19
Compound 4: the middle estimate sits 0.91 log units above what was measured; the whole stated range lies above it.
By their numbers in this assay, from the lowest: compounds 1 and 2 (each within the scatter of the next); then compound 4; then compound 3.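

In this assay, an exchange between two groups with no hydrogen-bond acceptors still gives a large step at this place, a number 1.62 log units lower from compound 3 to compound 4 (beyond the scatter), with 1-methylethenyl (3 heavy atoms, 1 double bond) entering for sec-butyl (4 heavy atoms). The same group stands clear of both oxygen-bearing groups, a number 0.65 log units higher from compound 1 to compound 4 (beyond the scatter) and a number 0.62 log units higher from compound 2 to compound 4 (beyond the scatter), so these all-carbon groups are not equivalent here. No measured evidence bears on the origin of these steps. On these data alone, an isopropyl group here would separate the effect of the double bond from that of the heavy-atom count, and how an amine or a longer chain would fall remains open.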